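Benzyl for Isopropyl on the Sulfonamide Nitrogen

A few compounds are considered here, and "the series" means these few. Any claim that something is new, unique, unknown or untested is made for them only; others in the source may bear on it.

Compound 2 `CC(C)NS(=O)(=O)c1ccc2c(c1)C(n1ccccc1=O)=CC(C)(C)O2` stands at 94.8% in a functional assay on the whole organism (trachea) with Rattus norvegicus as the target (a higher number here means a larger maximal response, a lower number a smaller maximal response), while compound 1 `CC1(C)C=C(n2ccccc2=O)c2cc(S(N)(=O)=O)ccc2O1` gives 92.1%, the two numbers lying within the scatter of each other. Among the compounds with values here, the only measured step, a number 2.7 percentage points higher from compound 1 to compound 2 (within the scatter), shows that putting isopropyl in place of hydrogen on the sulfonamide nitrogen left the maximal response essentially where it was. Compound 3 `CC1(C)C=C(n2ccccc2=O)c2cc(S(=O)(=O)NCc3ccccc3)ccc2O1` carries the next change at the same place: benzyl in place of isopropyl on a sulfonamide nitrogen. Within the data shown here, this step bears a likeness to the measured one, since both alter what sits on the sulfonamide nitrogen, but no measured step introduces a ring there, so the precedent is only partial. From compound 2 the expected step is a number 1.8 percentage points lower from compound 2 to compound 3 (within the scatter), a shift no larger than the scatter, with the range kept wide because only a number 2.7 percentage points higher from compound 1 to compound 2 (within the scatter) informs it. Compound 3 is therefore estimated at 93%, between 78% and 105%.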

Compound 3, largest response reached (Emax), in percent of the reference or control that the assay uses: 77.5%
For compound 3 the middle estimate is 15.5 percentage points above the measured one; the measured number lies below the stated range.
By their numbers in this assay, from the lowest: compound 3; then compounds 1 and 2 (each within the scatter of the next).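

The sulfonamide nitrogen proved not to be indifferent in this assay: the change to isopropyl had stayed within the scatter, but benzyl brought a fall beyond it, (a number 17.3 percentage points lower from compound 2 to compound 3 (beyond the scatter)) and (a number 14.6 percentage points lower from compound 1 to compound 3 (beyond the scatter)). Benzyl therefore stands apart from both hydrogen and isopropyl at this position, so a substituent here can lower the maximal response even though the first change did not. No measurement available here explains this fall.

Benzyl differs from isopropyl both in carrying an aromatic ring and in having more carbon atoms, and the compounds shown do not separate these two differences. A cyclohexylmethyl group or a straight hexyl chain on the same nitrogen would help tell them apart, while a phenyl group would show whether the methylene link matters.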